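Swapping an acetyl for two methyls on a fused core

A few compounds are considered here, and "the series" means these few. Any claim that something is new, unique, unknown or untested is made for them only; others in the source may bear on it.

Going by the values given here, compound 1 `COc1cc(-c2ccnc3cc(-c4ccc(C(C)=O)cc4)nn23)cc(OC)c1OC` is the only compound here with a measured number. In a functional assay on B16-F0 cells (Mus musculus) for inhibition, read by CCK-8 assay, with a stated time of 48 h (a higher number here means a weaker inhibitor, a lower number a stronger inhibitor), compound 1 gives 3930 nM. Compound 2 `Cc1ccc(-c2cc3nccc(-c4ccc(F)cc4)n3n2)cc1` shares the fused core but carries different groups on it. In this assay compound 2 reaches only a limit of the assay, > 10000 nM. Compound 2 thus sits at the limit of > 10000 nM in this assay, at which 1 of the 2 values shown sits. Compound 3 `COc1cc(-c2ccnc3cc(-c4ccc(C)c(C)c4)nn23)cc(OC)c1OC` has not yet been measured. It differs from compound 1 in one place: 3,4-dimethylphenyl in place of 4-acetylphenyl on an aromatic carbon. Among the compounds with values here, no measured pair in this set differs in only one place, so the size of this step has no direct precedent. Compound 3 is expected to come out somewhat weaker than compound 1, with a step that may still fall within the usual scatter. This expected step is a 1.5-fold higher number from compound 1 to compound 3 (0.18 log units; within the scatter). For compound 3 the estimate in this assay is 6000 nM, expected to lie between 2000 nM and 20000 nM.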

Compound 3, half-maximal inhibitory concentration: 391 nM
The estimate for compound 3 lay 15-fold (1.19 log units) above the measured number; the whole stated range lies above it.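

Swapping the group on this aromatic carbon of the five-membered ring clearly matters: in this assay, 3,4-dimethylphenyl in place of 4-acetylphenyl gives a 10-fold lower number from compound 1 to compound 3 (1.00 log units; beyond the scatter). Going by these compounds alone, compound 1 and compound 2 differ in more than one place, so this is the first single change whose size can be read, and it shows that a phenyl ring here need not carry a carbonyl for the number to fall. The entering group has no hydrogen-bond acceptor where the leaving group has one, but nothing measured here accounts for the gain.

As far as these compounds go, whether that gain comes from losing the acetyl or from gaining the two methyls stays open. Also open, from the compounds shown here alone, is how an amine or a carboxylic acid on this phenyl ring would compare with either group.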